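A few compounds are considered here, and "the series" means these few. Any claim that something is new, unique, unknown or untested is made for them only; others in the source may bear on it.

Measured compounds:

- compound 1, `COc1ccc(F)cc1CNCCCNc1ccnc2cc(Cc3cc(C)cc(C)c3)ccc12`: 4200 nM
- compound 2, `COc1cccc(Oc2ccc3c(NCCCNCc4cc(F)ccc4OC)ccnc3c2)c1`: 14500 nM

In a physicochemical assay for solubility, with a stated time of 18 h, at pH 7.4 (a lower number here means a less soluble compound, a higher number a more soluble compound), compound 1 gives the lower of the two numbers, with compound 2 giving 14500 nM as the nearest point. Going by the values given here, the single measured step, a 3.5-fold higher number from compound 1 to compound 2 (0.54 log units; beyond the scatter), sits on an aromatic carbon of the shared core.

Compound 3, `Cc1cc(C)cc(Cc2ccc3c(NCCCNCc4ccco4)ccnc3c2)c1`, is to be measured in this assay. It differs from compound 1 by furan-2-yl in place of 5-fluoro-2-methoxyphenyl on a saturated chain carbon bound to an amine nitrogen. Among the compounds with values here, this is a different position from the one probed by the step from compound 1 to compound 2, so no measured step bears on the change directly; the only guidance is that both measured numbers lie within a narrow window. Without a comparable step, the expected move is small, in either direction.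

Compound 3 is therefore estimated at 6000 nM, with a range of 2500 nM to 15000 nM. The implied step, a 1.4-fold higher number from compound 1 to compound 3 (0.15 log units; within the scatter), is expected to sit near the edge of the scatter rather than clearly beyond it.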

Compound 3, solubility: 4200 nM
Beside the measured number, compound 3's estimate is 1.4-fold (0.15 log units) above it; the range from low to high includes it.
By their numbers in this assay, from the lowest: compounds 1 and 3 (each within the scatter of the next); then compound 2.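

In this assay, furan-2-yl in place of 5-fluoro-2-methoxyphenyl on a saturated chain carbon bound to an amine nitrogen gives no change at the digits printed from compound 1 to compound 3 (within the scatter). Going by these compounds alone, this is the first reading at this position, and a drop from 9 heavy atoms to 5, with a six-membered carbon ring giving way to a five-membered ring with 1 hetero atom, leaves the number unmoved, whereas the only step beyond the scatter remains the one on an aromatic carbon, a 3.5-fold higher number from compound 1 to compound 2 (0.54 log units; beyond the scatter). No supporting data on hand explain why the number holds at this position.

Going by these compounds, it remains open whether a cyclohexyl group, a dimethylamino group or a carboxylic acid in the same place would also leave the number unmoved. On these data alone, the effect of furan-2-yl alongside 3-methoxyphenoxy on the shared core is also open.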